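Benzoyl to Acetyl: What to Expect for Compound 4

This account rests on a few compounds, and the source may have more. Where it says the series, first, only, none or still open, it means among the compounds named here.

Compound 1 `NC(=O)c1c(NC(=O)c2ccc(Cl)cc2)sc2c1CCN(C(=O)c1ccccc1)C2`: 42.5%
Compound 2 `CC(=O)N1CCc2c(sc(NC(=O)c3ccc(Cl)cc3)c2C(N)=O)C1`: 38.4%
Compound 3 `NC(=O)c1c(NC(=O)c2ccc(OCc3ccccc3)cc2)sc2c1CCN(C(=O)c1ccccc1)C2`: 13.7%

Of the compounds shown here, three have been measured in an ADME assay on RAW264.7 cells (Mus musculus) for cytotoxicity, read by MTT assay, with a stated time of 48 h, tested at 50 uM; a higher number here means more inhibition at the concentration tested (going by the name of the read-out), a lower number less inhibition. Compound 2 differs from compound 1 by methyl in place of phenyl on a carbonyl carbon, and the step of a number 4.1 percentage points lower from compound 1 to compound 2 (within the scatter) goes with it. Compound 3 differs from compound 1 by benzyloxy in place of chloro on an aromatic carbon, with the step of a number 28.8 percentage points lower from compound 1 to compound 3 (beyond the scatter), leaving compound 3 lowest of the three. Compound 4 `CC(=O)N1CCc2c(sc(NC(=O)c3ccc(OCc4ccccc4)cc3)c2C(N)=O)C1` has not yet been measured. It differs from compound 3 by methyl in place of phenyl on a carbonyl carbon, the same change as from compound 1 to compound 2, made at the same place. The step in this assay is expected to be small, a number 2.7 percentage points lower from compound 3 to compound 4 (within the scatter), because a number 4.1 percentage points lower from compound 1 to compound 2 (within the scatter) lay within the scatter. Compound 4 is therefore expected to give about 11%, most likely between 0% and 24%.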

Compound 4, a percentage reported as inhibition, at one concentration (the size of the read-out at that concentration, not a potency): 11.6%
Estimate against measurement, compound 4: 0.6 percentage points below, and the stated range covers the measured number.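

In this assay, the change from benzoyl to acetyl gave a number 2.1 percentage points lower from compound 3 to compound 4 (within the scatter), and it behaved alike on the two cores that carry it: the same change on two cores in this assay, a number 4.1 percentage points lower (within the scatter) from compound 1 to compound 2 and a number 2.1 percentage points lower (within the scatter) from compound 3 to compound 4, 2 percentage points apart, within the scatter of two such steps. Benzyloxy in place of chloro gave a number 26.8 percentage points lower from compound 2 to compound 4 (beyond the scatter), and that change also carried over: the same change on two cores in this assay, a number 28.8 percentage points lower (beyond the scatter) from compound 1 to compound 3 and a number 26.8 percentage points lower (beyond the scatter) from compound 2 to compound 4, 2 percentage points apart, within the scatter of two such steps. This holds for these four compounds only, with two changes seen on two cores each, and it does not show that either step would keep its size on a core bearing other groups.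

The compounds shown leave open whether a longer chain in place of the methyl of the acetyl would follow the same pattern. They also leave open what an amine or a carboxylic acid would give in place of the chloro or benzyloxy.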